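This account rests on a few compounds, and the source may have more. Where it says the series, first, only, none or still open, it means among the compounds named here.

Measured in a functional assay on DU-145 cells (Homo sapiens) for cytotoxicity, read by MTT assay, with a stated time of 24 h; a higher number here means a weaker inhibitor, a lower number a stronger inhibitor:

- Compound 1 `CCCCCCCC/C=C\CCCCCCCC(=O)Nc1nnc(S[C@@H]2O[C@H](CO)[C@H](O)[C@H](O)[C@H]2O)s1`: "not active" (no number reported)
- Compound 2 `C=CCCCCCCCCC(=O)Nc1nnc(S[C@@H]2O[C@H](COC(C)=O)[C@H](OC(C)=O)[C@H](OC(C)=O)[C@H]2OC(C)=O)s1`: 22900 nM
- Compound 3 `CCCCCCCC/C=C\CCCCCCCCCCCC(=O)Nc1nnc(S[C@@H]2O[C@H](CO)[C@H](O)[C@H](O)[C@H]2O)s1`: "not active" (no number reported)

Compound 1 stands without a number on this read-out. Its result is a bare qualitative entry, and compound 3 shares that position with "not active" (no number reported). Among the measured compounds shown here, only compound 2 gives a figure, at 22900 nM, so the series offers no measured step to serve as a yardstick.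

The next compound to be considered is compound 4 `C=CCCCCCCCCC(=O)Nc1nnc(S[C@@H]2O[C@H](CO)[C@H](O)[C@H](O)[C@H]2O)s1`, which departs from compound 1 in a single place: allyl in place of dec-1-en-1-yl on a saturated chain carbon, seven bonds along the chain from a carbonyl carbon. Allyl stands in place of dec-1-en-1-yl, on a saturated chain carbon, seven bonds along the chain from a carbonyl carbon.

For the measured compounds named here, with no measured step available, the expectation in this assay has to stay modest. Compound 3 reads as "not active" (no number reported) and compound 1 reads as "not active" (no number reported) despite their different chains, so no large gain in potency is expected from this change. If any movement appears, it is expected to be small and towards a measurable but weak result, and a further entry with no number would be quite plausible. Compound 4 is estimated at 50000 nM, with an expected range from 20000 nM to 150000 nM.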

Compound 4, half-maximal inhibitory concentration: "not active" (no number reported)
Compound 4: no number reported, and the estimate cannot be compared.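

In this assay, among the compounds shown here, compound 1 gives "not active" (no number reported) and compound 4 gives "not active" (no number reported) with no step to be read between them. No evidence bearing on this result is available. The compounds shown leave open whether replacing dec-1-en-1-yl with allyl has any effect on this read-out at all.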